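The compounds below may be only part of what the source reports. "The series", "measured", "known", "first", "only" and "open" are said of these compounds alone.

Series notes. Two compounds carry numbers in a functional assay on SW1573 cells (Homo sapiens) for antiproliferative activity, read by sulforhodamine B assay, with a stated time of 48 h; a lower number here means a stronger inhibitor of growth, a higher number a weaker inhibitor of growth. Compound 1 `COc1cc(-c2cc(CO[C@@H]3O[C@H](CSc4ncn[nH]4)[C@H]4OC5(CCCC5)O[C@@H]34)on2)cc(OC)c1OC` gives 97000 nM. Compound 2 `O=[N+]([O-])c1ccc(-c2nc(CO[C@@H]3O[C@H](CO)[C@H]4OC5(CCCC5)O[C@@H]34)no2)cc1` gives 27000 nM, the lower of the two numbers, and the gap to compound 1 is beyond the scatter. Within the data shown here, no single-change step between these two measured compounds is available, since they differ in more than one place.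

Compound 3 `CC(=O)OC[C@H]1O[C@@H](OCc2noc(-c3ccc([N+](=O)[O-])cc3)n2)[C@@H]2OC3(CCCC3)O[C@@H]21` has not been measured. Against compound 2 the change is acetyl in place of hydrogen on an oxygen on a saturated carbon. Among the measured compounds shown here, the numbers for compound 1 and compound 2 say nothing about this position, so no measured step guides the expectation. A change of this size at the hydroxymethyl is expected to move this assay only little, and in no firm direction, so compound 3 is estimated to sit close to compound 2, with the expected step being a 1.2-fold lower number from compound 2 to compound 3 (0.09 log units; within the scatter). Compound 3 is therefore expected at about 22000 nM, with a plausible range from 7000 nM to 70000 nM.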

Compound 3, concentration for 50% growth inhibition: 29000 nM
Beside the measured number, compound 3's estimate is 1.3-fold (0.12 log units) below it; measured number inside the range.
By their numbers in this assay, from the lowest: compounds 2 and 3 (each within the scatter of the next); then compound 1.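

Among these compounds, this is the only single-change reading at this position: in this assay the step is small (a 1.1-fold higher number from compound 2 to compound 3 (0.03 log units; within the scatter)) and lies within the scatter. For this pair, the hydroxymethyl and the acetoxymethyl cannot be told apart, so the hydrogen on this oxygen is not needed to keep the number at the level of compound 2. No measurement shown here offers an explanation for this flat step.

Still open, as far as these compounds go, is whether a carboxylic acid or an amine at this position, or a longer chain in place of acetyl, would move the number beyond the scatter. Also open, from the compounds shown here alone, is whether the same change would read alike on the core of compound 1, which differs from compound 2 in more than one place.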